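A few compounds are considered here, and "the series" means these few. Any claim that something is new, unique, unknown or untested is made for them only; others in the source may bear on it.

Measured in a physicochemical assay for solubility, read by HPLC, measured as thermodynamic solubility, with a stated time of 4 h, at pH 6.8; a lower number here means a less soluble compound, a higher number a more soluble compound:
- compound 1 `Cn1c(COc2cccc(C(=O)O)c2)nc2ccc(Oc3ccc(Cl)cn3)cc21`: 17 ug/mL
- compound 2 `Cn1c(COc2cccc(C(=O)O)c2)nc2ccc(Oc3ccc(F)cn3)cc21`: 79 ug/mL

Of these two, compound 2 stands highest at 79 ug/mL. Compound 3 `Cc1cnc(Oc2ccc3nc(COc4cccc(C(=O)O)c4)n(C)c3c2)c(F)c1` is not yet measured. It differs from compound 2 as follows: 3-fluoro-5-methylpyridin-2-yl in place of 5-fluoropyridin-2-yl on an oxygen on an aromatic ring. Within the data shown here, only one measured step bears on this, a 4.6-fold higher number from compound 1 to compound 2 (0.67 log units; beyond the scatter), a modest one with fluoro in place of chloro on an aromatic carbon. Among the measured compounds shown here, it matches the new change only in part, since no measured compound carries the methyl. A modest fall in this assay is therefore expected, and the expected step is a 2.3-fold lower number from compound 2 to compound 3 (0.35 log units; beyond the scatter). For compound 3 the estimate is 35 ug/mL, with an expected range from 12 ug/mL to 90 ug/mL.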

Compound 3, solubility: 9.2 ug/mL
Beside the measured number, compound 3's estimate is 3.8-fold (0.58 log units) above it; the whole stated range lies above it.
By their numbers in this assay, from the lowest: compounds 3 and 1 (each within the scatter of the next); then compound 2.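

The move to 3-fluoro-5-methylpyridin-2-yl on the oxygen gives an 8.6-fold lower number from compound 2 to compound 3 (0.93 log units; beyond the scatter) in this assay and shows that a change at this place can also lower the number, where the earlier step showed only a rise. Measured against 5-chloropyridin-2-yl, the same group gives a 1.8-fold lower number from compound 1 to compound 3 (0.27 log units; within the scatter) and so leaves no clear gap between those two compounds. Nothing available gives a reason for either step.

Going by these compounds, the fluoro and methyl groups enter together, so their separate shares in the step stay open. Also open, on these data alone, is how an amine or a methoxy group would read on this ring.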